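Swapping the aryl group on the shared core: compound 4

This account rests on a few compounds, and the source may have more. Where it says the series, first, only, none or still open, it means among the compounds named here.

Measured compounds:
compound 1 `COc1cc2c(Oc3ccc(NC(=O)c4nn(-c5ccc(Br)cc5)c(=O)c5ccccc45)cc3F)ccnc2cc1OCCCN1CCCCC1`, 770 nM
compound 2 `COc1cc2c(Oc3ccc(NC(=O)c4nn(-c5ccc(F)cc5)c(=O)c5ccccc45)cc3F)ccnc2cc1OCCCN1CCC(C)CC1`, 330 nM
compound 3 `COc1cc2c(Oc3ccc(NC(=O)c4nn(-c5cccc(F)c5)c(=O)c5ccccc45)cc3F)ccnc2cc1OCCCN1CCC(C)CC1`, 500 nM

All three were tested in a functional assay on HT-29 cells (Homo sapiens) for cytotoxicity, read by MTT assay, with a stated time of 72 h; on this read-out lower numbers stand for stronger inhibition and higher numbers for weaker inhibition. Compound 3 gives 500 nM, and its number sits between those of compound 2 and compound 1, with all three values inside the scatter of each other, so none of them can be called stronger or weaker.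

The next compound, compound 4 `COc1cc2c(Oc3ccc(NC(=O)c4nn(-c5ccc(Br)cc5)c(=O)c5ccccc45)cc3F)ccnc2cc1OCCCN1CCC(C)CC1`, differs from compound 3 in one place: 4-bromophenyl in place of 3-fluorophenyl on an aromatic nitrogen. Among the compounds with values here, only one measured step speaks to this kind of change, the move of a fluorine around the same ring, a 1.5-fold higher number from compound 2 to compound 3 (0.18 log units; within the scatter), and it stayed within the scatter. Within the data shown here, no step isolates bromine against fluorine. Compound 4 shares its 4-bromophenyl with compound 1, which carries a plain piperidine instead, and compound 1 gives 770 nM, close to the others.

Compound 4 is therefore expected to show no step beyond the scatter, a 1.0-fold higher number from compound 3 to compound 4 (0.02 log units; within the scatter). The estimated value of compound 4 is 520 nM, with a range from 250 nM to 1100 nM.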

Compound 4, half-maximal inhibitory concentration: 920 nM
Beside the measured number, compound 4's estimate is 1.8-fold (0.25 log units) below it; measured number inside the range.
By their numbers in this assay, from the lowest: compounds 2, 3, 1 and 4 (each within the scatter of the next, the first and the last beyond it).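

In this assay, within the data shown here, exchanging the 4-fluorophenyl for a 4-bromophenyl, bromo in place of fluoro, gives a 2.8-fold higher number from compound 2 to compound 4 (0.45 log units; beyond the scatter) and so weakens inhibition, the first step on this aryl group to pass the scatter. The change from 3-fluorophenyl to 4-bromophenyl alters both the halogen and its ring position, and it gives a 1.8-fold higher number from compound 3 to compound 4 (0.26 log units; within the scatter) with no reliable change. Adding a methyl to the saturated ring gives a 1.2-fold higher number from compound 1 to compound 4 (0.08 log units; within the scatter) and likewise no reliable change, so among these single changes only bromo for fluoro gives a readable shift. Nothing available explains this shift.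

As far as these compounds go, it remains open whether a 4-chlorophenyl would fall closer to the fluoro or the bromo compound. The effect of an amine or a carboxylic acid on this aryl ring is also unknown.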